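The compounds below may be only part of what the source reports. "The series", "measured", "known", "first", "only" and "open" are said of these compounds alone.

Among the measured compounds shown here, compound 1 `CC(C)[C@H](C[C@H]1CCNC1=O)c1ccc(-c2ccc3cccc(F)c3c2)[nH]c1=O` is the only compound of this set with a number attached to it: in an ADME assay on microsomes from liver (Rattus norvegicus) for metabolic stability (on this read-out higher numbers stand for a longer-lived compound and lower numbers for a shorter-lived compound), compound 1 gives 0.227 h. Compound 2 `CC(C)C(CC(N)=O)c1ccc(-c2ccc3cccc(F)c3c2)[nH]c1=O` has been run in the same assay, but without a number coming out of it. In this assay compound 2 gives < 0.0667 h, which is a limit of the assay and not a number, so it marks only (the limit of < 0.0667 h in this assay, at which 1 of the 2 values shown sits). Nothing more can be said of how compound 1 and compound 2 relate than what these two values show.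

Compound 3 `CC(C)[C@@H](C[C@H]1CCNC1=O)c1ccc(-c2ccc3cccc(F)c3c2)[nH]c1=O` has not yet been measured. It stands next to compound 1 in a single respect: the two compounds have the same atoms and bonds and differ only in configuration as drawn: 1 of 2 stereo elements differ; a stereocentre at a saturated chain carbon is drawn S in compound 1 and R in compound 3. For the measured compounds named here, no step between measured compounds here pairs such a change of configuration with a number, so there is no precedent to draw on. The step of a 1.0-fold lower number from compound 1 to compound 3 (0.01 log units; within the scatter) is therefore expected to be small, with neither direction favoured and no movement beyond the usual scatter. On that basis compound 3 is expected to give 0.22 h in this assay, with a range from 0.08 h to 0.6 h.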

Compound 3, half-life in the Rattus norvegicus assay: 0.507 h
The estimate for compound 3 lay 2.3-fold (0.36 log units) below the measured number; the measured number falls inside the stated range.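

Drawing the saturated chain carbon as R rather than S gives a 2.2-fold higher number from compound 1 to compound 3 (0.35 log units; beyond the scatter) in the Rattus norvegicus assay and so provides the first sign in this set that the configuration at this position can change the read-out beyond the usual scatter. The same change leaves solubility within the scatter: in a physicochemical assay for solubility, in phosphate buffer, measured as kinetic solubility (on this read-out lower numbers stand for lower solubility and higher numbers for higher solubility), compound 1 gives 26800 nM and compound 3 gives 32000 nM as the pair's two values, so here the configuration moves half-life without a matching step in solubility. The step in half-life can be assigned to this one stereocentre because nothing else separates the pair: the fact that compounds 1 and 3 differ only in the configuration as drawn.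

The other stereo element is drawn the same in compound 1 and compound 3, so the compounds shown leave open how the read-outs would respond if it were inverted, alone or together with the chain carbon. They also leave open whether the R drawing would keep its longer half-life with a cyclopropyl group or a longer chain in place of the isopropyl group, or with a carboxylic acid on the chain.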